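A few compounds are considered here, and "the series" means these few. Any claim that something is new, unique, unknown or untested is made for them only; others in the source may bear on it.

Series notes. Three compounds have been run in a functional assay on CHO cells for agonist activity at Alpha-2C adrenergic receptor (Homo sapiens); a lower number here means a smaller maximal response, a higher number a larger maximal response. Compound 1 is `CC(Oc1ccccc1-c1ccccc1)C1=NCCO1`, and in this assay compound 1 gives only a limit, < 0.3. Compound 2 is `CC(Oc1ccccc1-c1ccc(O)cc1)C1=NCCN1`, and in this assay compound 2 likewise gives only a limit, < 0.3. Compound 3 is `CC(Sc1ccccc1-c1ccccc1)C1=NCCN1`, and in this assay compound 3 also gives only a limit, < 0.3. Among the compounds with values here, no pair among compounds 1, 2 and 3 differs in a single place, so no measured step is available. Where compound 2 stands can be said only this far: its value is a limit, as are the two others shown, (the limit of < 0.3 in this assay, at which 3 of the 3 values shown sit).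

Compound 4, `Cc1ccc(-c2ccccc2OC(C)C2=NCCN2)cc1`, has not yet been measured in this assay. From compound 2 it differs by methyl in place of hydroxy on an aromatic carbon. With every measured compound sitting at the limit, the expected step from compound 2 to compound 4 in this assay, a step that the limit leaves unreadable from compound 2 to compound 4, is none beyond the scatter. Within the data shown here, a maximal response above the limit would be new to this series, and nothing measured so far points to it. Compound 4 is therefore expected to give an intrinsic activity of about 0.2, within a range from 0.05 to 0.45, most likely reported again only as a limit.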

Compound 4, intrinsic activity: the largest response reached, as a fraction of the reference agonist's: 0.46
Estimate against measurement, compound 4: 0.26 below, outside the stated range (above it).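

Replacing hydroxy with methyl on an aromatic carbon, para to a large group, gives in this assay a number at least partly free of the limit, with a number at least 0.16 higher from compound 2 to compound 4 (beyond the scatter). This place on the shared core therefore affects the maximal response, and compound 4 is the only one of the four compounds shown to give a number rather than a limit, so a response that can be read is possible in this series. The change takes out 1 hydrogen-bond donor and 1 hydrogen-bond acceptor, but the full size of the step cannot be given because compound 2 carries only a limit: the limit of < 0.3 in this assay, at which 3 of the 4 values shown sit.

As far as these compounds go, it remains open whether the response comes from the presence of methyl or the absence of hydroxy, and a plain hydrogen, a chlorine, a methoxy group or an ethyl group at the same place would help to separate the two. From the compounds shown here alone, it also remains open whether 4-methylphenyl would lift the response on the cores of compound 1 and compound 3, which differ from compound 4 in more than one place.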